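The source may hold more compounds than are shown below. What is called first, only, known or untested is meant among the compounds shown, and "the series" means these compounds.

Two compounds with the same core differ only in the ring attached to the amide-type nitrogen. Going by the values given here, in a functional assay on the whole organism (strain Wistar) for inhibition, with Rattus norvegicus as the target, read by paw edema, with a stated time of 6 h, at a dose of 100 mg/kg (a higher number here means more inhibition at the dose given (going by the name of the read-out), a lower number less inhibition), compound 1 `COc1cc2c(cc1OC)C(CC(=O)Nc1cccc(Cl)c1)CC2` gives 38.9%, the higher of the two numbers measured so far. Compound 2 `COc1cc2c(cc1OC)C(CC(=O)Nc1ccccc1C)CC2` gives 25.9% in this assay, and the change from compound 1 to compound 2, 2-methylphenyl in place of 3-chlorophenyl on an amide-type nitrogen, gave a number 13 percentage points lower from compound 1 to compound 2 (beyond the scatter).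

Compound 3 `COc1ccccc1NC(=O)CC1CCc2cc(OC)c(OC)cc21` is not yet measured. Compared with compound 1 it carries 2-methoxyphenyl in place of 3-chlorophenyl on an amide-type nitrogen. Among the compounds with values here, the one measured step that bears on this move is the one from compound 1 to compound 2, which also replaced the 3-chlorophenyl with a ring bearing a single group, and it lowered the number modestly. A drop of similar size is therefore expected, so that the step of a number 10.9 percentage points lower from compound 1 to compound 3 (beyond the scatter) is estimated. Compound 3 is expected to give about 28%, somewhere between 15% and 42%.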

Compound 3, a percentage reported as inhibition, in the whole organism at one dose (the size of the read-out at that dose, not a potency): 24.1%
The estimate for compound 3 lay 3.9 percentage points above the measured number; low and high end bracket the measured number.
By their numbers in this assay, from the lowest: compounds 3 and 2 (each within the scatter of the next); then compound 1.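

In this assay, 2-methoxyphenyl in place of 3-chlorophenyl on the amide-type nitrogen gives a number 14.8 percentage points lower from compound 1 to compound 3 (beyond the scatter), so a second replacement of the 3-chlorophenyl also lowers the number and compound 1 remains the highest of the three. Methoxy in place of methyl on an aromatic carbon gives a number 1.8 percentage points lower from compound 2 to compound 3 (within the scatter), so these two groups cannot be told apart in this assay. No measurement at hand accounts for these numbers.

Going by these compounds, the 3-chlorophenyl differs from both replacements in its group and in the numbered place of that group, so it remains open which of the two matters; a 2-chlorophenyl or a 3-methoxyphenyl would separate them. Also open, on these data alone, is how a phenyl ring carrying an amine or a carboxylic acid would fare at this position.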